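Series notes: solubility when sulfamoyl gives way to carboxyazetidinylmethyl

The compounds below may be only part of what the source reports. "The series", "measured", "known", "first", "only" and "open" are said of these compounds alone.

Measured so far:
compound 1 `Cc1cc(S(N)(=O)=O)ccc1NC(=O)c1cc(NC2CCCCC2)ncn1`: 5 ug/mL
compound 2 `Cc1cc(S(N)(=O)=O)ccc1NC(=O)c1cc(N(CC2CC2)C2CCCCC2)ncn1`: 1 ug/mL

Among the measured compounds shown here, in a physicochemical assay for solubility, read by nephelometry, in phosphate buffer (on this read-out higher numbers stand for higher solubility and lower numbers for lower solubility), compound 2 holds the lowest of the two numbers; the one measured step, a 5.0-fold lower number from compound 1 to compound 2 (0.70 log units; beyond the scatter), concerns a different site and touches neither group exchanged here. Compound 3 `Cc1cc(CN2CC(C(=O)O)C2)ccc1NC(=O)c1cc(N(CC2CC2)C2CCCCC2)ncn1` carries (3-carboxyazetidin-1-yl)methyl in place of sulfamoyl on an aromatic carbon. For the measured compounds named here, no measured pair speaks to this exchange, so the expectation rests on the structural change alone. A rise in this assay is expected for compound 3, estimated at a 30-fold higher number from compound 2 to compound 3 (1.48 log units; beyond the scatter), giving an expected value of 30 ug/mL within 5 ug/mL to 150 ug/mL.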

Compound 3, solubility: 22 ug/mL
The estimate for compound 3 lay 1.4-fold (0.13 log units) above the measured number, and the stated range covers the measured number.
By their numbers in this assay, from the lowest: compound 2; then compound 1; then compound 3.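

In this assay, the position para to a large group proves responsive: (3-carboxyazetidin-1-yl)methyl in place of sulfamoyl gives a 22-fold higher number from compound 2 to compound 3 (1.34 log units; beyond the scatter) in the background of the cyclopropylmethyl-bearing nitrogen. The step arises with the hydrogen-bond donor and acceptor counts unchanged and no net charge on either group. Nothing measured here accounts for its size.

Still open, going by these compounds, is whether the gain follows the carboxylic acid or the ring amine, which a dimethylaminomethyl group or a simple carboxymethyl group at this position would help separate. Also open, on these data alone, is whether the exchange carries over to the core of compound 1.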